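This account rests on a few compounds, and the source may have more. Where it says the series, first, only, none or still open, it means among the compounds named here.

Measured compounds:
- Compound 1, `O=C(O)[C@H]1CC[C@](F)(C(=O)N2CC[C@](c3ccc(C(F)(C(F)(F)F)C(F)(F)F)cc3)(S(=O)(=O)c3ccc(F)cc3)C2)CC1`: "not determined" (no result reported)
- Compound 2, `O=C(N1CC[C@](c2ccc(C(F)(C(F)(F)F)C(F)(F)F)cc2)(S(=O)(=O)c2ccc(F)cc2)C1)C12CCC(C(=O)O)(CC1)OC2`: "not determined" (no result reported)
- Compound 3, `CS(=O)(=O)C1CCC(C(=O)N2CC[C@](c3ccc(C(F)(C(F)(F)F)C(F)(F)F)cc3)(S(=O)(=O)c3ccc(F)cc3)C2)CC1`: 88%; 100% (2 entries)

In an ADME assay on microsomes from liver (Homo sapiens) for metabolic stability, with a stated time of 10 min (on this read-out lower numbers stand for a less stable compound and higher numbers for a more stable compound), compound 1 stands without a single number, and compound 2 likewise gives "not determined" (no result reported). For the measured compounds named here, the only compound of the shared core with a result is compound 3, which in this assay gives 88%; 100% (2 entries); the two entries of compound 3 lie within the usual scatter of each other, as the several entries of compound 3 in this assay, 88%; 100% (2 entries) shows.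

Compound 4, `O=C([C@H]1CC[C@H](CO)CC1)N1CC[C@](c2ccc(C(F)(C(F)(F)F)C(F)(F)F)cc2)(S(=O)(=O)c2ccc(F)cc2)C1`, has not been measured. It differs from compound 1 in one place: 4-(hydroxymethyl)cyclohexyl in place of 4-carboxy-1-fluorocyclohexyl on a carbonyl carbon. Going by the values given here, since compound 1 has no number in this assay, no step from compound 1 to compound 4 can be sized, nor given a direction, from the figures at hand; what can be said is that a compound of the same core, compound 3, is found near the top of the scale.

On that basis compound 4 is expected to remain largely intact in this assay, with an estimate of 80% and a range from 55% to 100%.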

Compound 4, percent of the compound remaining: 75%
Compound 4: middle estimate off by 5 percentage points, on the high side; the measured number falls inside the stated range.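

In this assay, for the compounds shown here, compound 1 gives "not determined" (no result reported), so no step from compound 1 to compound 4 can be read. The compounds shown leave open how 4-(hydroxymethyl)cyclohexyl in place of 4-carboxy-1-fluorocyclohexyl on the carbonyl carbon alters the percent of compound remaining.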